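This account rests on a few compounds, and the source may have more. Where it says the series, first, only, none or still open, it means among the compounds named here.

Measured so far in a functional assay on NCI-H460 cells (Homo sapiens) for cytotoxicity, read by MTT assay, with a stated time of 48 h; a lower number here means a stronger inhibitor, a higher number a weaker inhibitor:

- Compound 1 `C=C1C(=O)O[C@H]2CC3=C[C@H](C/C(C)=C/[C@@H](OC(=O)c4ccc(C(F)(F)F)cc4)[C@H]12)OC3=O`: > 10000 nM (a limit)
- Compound 2 `C=C1C(=O)O[C@H]2CC3=C[C@H](C/C(C)=C/[C@@H](OC(=O)/C=C/c4ccccc4)[C@H]12)OC3=O`: > 10000 nM (a limit)
- Compound 3 `C=C1C(=O)O[C@H]2CC3=C[C@H](C/C(C)=C/[C@@H](OC(=O)CCCCBr)[C@H]12)OC3=O`: > 10000 nM (a limit)

These three compounds share one core and differ only in the group on a carbonyl carbon. Compound 3 stands at > 10000 nM, which is a limit and not a number. The whole set sits at one point: the limit of > 10000 nM in this assay, at which 3 of the 3 values shown sit. Compound 3 therefore cannot be ranked against compound 1 or compound 2.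

Compound 4 `C=C1C(=O)O[C@H]2CC3=C[C@H](C/C(C)=C/[C@@H](OC(=O)CCCCC)[C@H]12)OC3=O` keeps the chain of compound 3 but swaps the atom at its end: methyl in place of bromo on a saturated chain carbon, four bonds along the chain from a carbonyl carbon. In words, this is methyl in place of bromo on a saturated chain carbon, four bonds along the chain from a carbonyl carbon. Cut one bond further out, the same difference reads 3-bromopropyl to butyl.

The measured steps that bear on this chain are a step that the two limits leave unreadable from compound 1 to compound 3 and a step that the two limits leave unreadable from compound 2 to compound 3. Neither has a readable size, so neither offers a size or direction to carry over. The expected step is a step that the limit leaves unreadable from compound 3 to compound 4, which means no change beyond the scatter is expected in either direction. For compound 4 the estimated value is 15000 nM, with an expected range of 6000 nM to 40000 nM.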

Compound 4, half-maximal inhibitory concentration: 5900 nM
For compound 4 the middle estimate is 2.5-fold (0.41 log units) above the measured one; measured number below the stated range.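

In this assay compound 4 gives 5900 nM, the only true number among the compounds shown, and methyl in place of bromo on a saturated chain carbon, four bonds along the chain from a carbonyl carbon, gives an at least 1.6-fold lower number from compound 3 to compound 4 (0.22 log units; that floor lies within the scatter). Pentyl in place of 2-phenylethenyl gives an at least 1.6-fold lower number from compound 2 to compound 4 (0.22 log units; that floor lies within the scatter), and pentyl in place of 4-(trifluoromethyl)phenyl gives an at least 1.6-fold lower number from compound 1 to compound 4 (0.22 log units; that floor lies within the scatter). The steps among compound 1, compound 2 and compound 3 cannot be read, and the three new steps are floors and not sizes, so the new fact is only that this one change at the end of the chain yields a number and not a limit, against a set that otherwise sits at one point: the limit of > 10000 nM in this assay, at which 3 of the 4 values shown sit.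

On these data alone, whether a chloro or a hydroxyl at the end of the same chain would behave like the bromo of compound 3 or the methyl of compound 4 stays open, as does the effect of a longer chain such as heptyl. As far as these compounds go, with a single number in the set, no trend along the chain can be drawn, and how far compound 4 truly stands from the other three remains unknown.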